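Isoflavone ether chain variation and monoamine oxidase inhibition

A few compounds are considered here, and "the series" means these few. Any claim that something is new, unique, unknown or untested is made for them only; others in the source may bear on it.

Measured compounds:
compound 1, `O=c1c(-c2ccc(O)cc2)coc2cc(OCCCCCCBr)ccc12`, 95.7%
compound 2, `O=c1c(-c2ccc(O)cc2)coc2cc(OCCC3OCCCO3)ccc12`, 88.5%
compound 3, `C=CCOc1ccc2c(=O)c(-c3ccc(O)cc3)coc2c1`, 100%

In a functional assay on mitochondria (Cricetulus griseus) for inhibition of Monoamine oxidase (Homo sapiens), tested at 9 uM (a higher number here means a stronger effect of the compound at the concentration tested, a lower number a weaker effect), compound 3 holds the highest of the three numbers; the two steps leading to it are a number 4.3 percentage points higher from compound 1 to compound 3 (within the scatter) and a number 11.5 percentage points higher from compound 2 to compound 3 (beyond the scatter). Compound 4, `O=C(O)CCCCCCOc1ccc2c(=O)c(-c3ccc(O)cc3)coc2c1`, differs from compound 3 by 5-carboxypentyl in place of vinyl on a saturated chain carbon bound to an oxygen on an aromatic ring. The relevant steps are the chain exchanges already seen: a number 4.3 percentage points higher from compound 1 to compound 3 (within the scatter) and a number 11.5 percentage points higher from compound 2 to compound 3 (beyond the scatter), one within and one modestly beyond the scatter. A longer chain ending in a carboxylic acid is thus expected to cost little at most, with the step estimated as a number 12 percentage points lower from compound 3 to compound 4 (beyond the scatter). Compound 4 is expected to give about 88% in this assay, in the range 72% to 100%.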

Compound 4, a percentage reported as inhibition, at one concentration (the size of the read-out at that concentration, not a potency): 94.6%
Beside the measured number, compound 4's estimate is 6.6 percentage points below it; the range from low to high includes it.
By their numbers in this assay, from the lowest: compounds 2, 4, 1 and 3 (each within the scatter of the next, the first and the last beyond it).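

In this assay, 5-carboxypentyl in place of vinyl gives a number 5.4 percentage points lower from compound 3 to compound 4 (within the scatter), so this ether position accepts a much longer chain ending in a carboxylic acid. Carboxy in place of bromo at the chain end gives a number 1.1 percentage points lower from compound 1 to compound 4 (within the scatter), and the open acid chain in place of the chain carrying the six-membered ring gives a number 6.1 percentage points higher from compound 2 to compound 4 (within the scatter), so no change in the chain end separates these pairs. Values this close at one concentration leave potency differences unresolved, and an amine at the chain end remains open. Nothing available explains these steps.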